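The source may hold more compounds than are shown below. What is called first, only, known or untested is meant among the compounds shown, and "the series" means these compounds.

Compound 1 `O=C(Nc1ccc(Cl)cc1)C1(c2ccc3c(n2)CCN3c2ccccn2)CCC1` was tested in an assay on blood for inhibition of Indoleamine 2,3-dioxygenase 1 (Homo sapiens) (a lower number here means a stronger inhibitor, a higher number a weaker inhibitor), where compound 1 gives 340 nM. Two other compounds sit near it: compound 2 `O=C(NC1(c2ccc3c(n2)CCN3C(=O)OC2CC2)CC1)c1ccc(Cl)cc1` gives 390 nM in this assay, and compound 3 `O=C(Nc1ccc(Cl)cc1)C1(c2ccc3c(c2)CCN3c2ccccn2)CCC1` gives 640 nM. All three numbers lie within the usual scatter of one another, so no one of them can be called stronger or weaker.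

Compound 4 `O=C(OC1CC1)N1CCc2nc(C3(C(=O)Nc4ccc(Cl)cc4)CCC3)ccc21` has not yet been measured. It differs from compound 1 by one change: cyclopropyloxycarbonyl in place of pyridin-2-yl on a nitrogen on an aromatic ring in a ring. Compound 2 already carries a cyclopropyloxycarbonyl group and gives 390 nM, a number close to compound 1, so no step beyond the scatter is expected for a 1.2-fold higher number from compound 1 to compound 4 (0.07 log units; within the scatter). Compound 4 is therefore estimated at 400 nM, with a likely range from 180 nM to 900 nM.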

Compound 4, half-maximal inhibitory concentration: 90 nM
Compound 4: the middle estimate sits 4.4-fold (0.65 log units) above what was measured; the measured number lies below the stated range.
By their numbers in this assay, from the lowest: compound 4; then compounds 1, 2 and 3 (each within the scatter of the next).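

In this assay, putting cyclopropyloxycarbonyl in place of pyridin-2-yl on this nitrogen gives a 3.8-fold lower number from compound 1 to compound 4 (0.58 log units; beyond the scatter), so the group at this position does matter. The two groups hold the same number of heavy atoms, so the step comes without any change in that count. Nothing measured here explains the step.

Which part of cyclopropyloxycarbonyl goes with the lower number, the carbonyl or the three-membered ring, remains open. So does how an acetyl group or a simple ethyl chain on this nitrogen would compare.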